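The source may report more compounds than this note shows. Statements on the series, on what has been measured and on what is new or still open speak of the compounds shown alone.

Of the compounds shown here, three built on a shared core have been tested in an assay on CHO cells for displacement of a labelled ligand from adenosine receptor A3 (Homo sapiens), read by scintillation counting, tested at 10 uM; a lower number here means less inhibition, a higher number more inhibition at the concentration tested (going by the name of the read-out). Compound 1 `CC(C)(C)c1csc(N)c1C(=O)c1ccc(Cl)cc1` gives 1%. Compound 2 `CC(C)(C)Cc1c(-c2ccccn2)sc(N)c1C(=O)c1ccc(Cl)cc1` gives 1% in this assay, and compound 3 `Cc1ccc(C(=O)c2c(N)sc(Br)c2CC(C)(C)C)cc1` gives 1%. Compound 2 therefore stands level with compounds 1 and 3, all three within the usual scatter of one another. Compound 4 `CC(C)(C)Cc1c(-c2ccccc2)sc(N)c1C(=O)c1ccc(Cl)cc1` differs from compound 2 in a single place: phenyl in place of pyridin-2-yl on an aromatic carbon. Going by the values given here, no step between measured compounds bears on this change, and none of the three measured compounds shows inhibition beyond the scatter, so no direction can be read from the data. Compound 4 is expected to behave like compound 2, with a step of a number 1 percentage points higher from compound 2 to compound 4 (within the scatter) in this assay that stays within the scatter. The estimate for compound 4 is 2%, ranging from -8% to 12%.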

Compound 4, a percentage reported as inhibition, at one concentration (the size of the read-out at that concentration, not a potency): 1%
Beside the measured number, compound 4's estimate is 1 percentage points above it, and the stated range covers the measured number.
By their numbers in this assay, from the lowest: compounds 1, 2, 3 and 4 (each within the scatter of the next).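

Replacing pyridin-2-yl with phenyl next to the ring sulfur gives no change at the digits printed from compound 2 to compound 4 (within the scatter) in this assay, so losing the ring nitrogen does not shift this read-out. With compound 4 level with the other three, neither aromatic ring at this place has produced inhibition beyond the scatter. No other data bear on this result.

On these data alone, whether any group here can produce clear inhibition stays open, and a carboxylic acid or a morpholine ring on this carbon would test that. Also open, as far as these compounds go, is whether the same swap would matter in a compound with clear inhibition.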